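This account rests on a few compounds, and the source may have more. Where it says the series, first, only, none or still open, it means among the compounds named here.

Compound 2, `c1ccc2sc(Nc3nc4ccccc4s3)nc2c1`, shares its core with compound 1, `CCOc1ccc2nc(Nc3nc4ccccc4s3)sc2c1`; in a functional assay on THP-1 cells (Homo sapiens) for cytotoxicity, read by MTT assay, with a stated time of 48 h (on this read-out lower numbers stand for stronger inhibition and higher numbers for weaker inhibition), compound 2 gives 28800 nM, while compound 1 gives 37100 nM. The change between them, (ethoxy in place of hydrogen on an aromatic carbon), made a 1.3-fold higher number from compound 2 to compound 1 (0.11 log units; within the scatter). Compound 3, `S=C(Nc1ccccc1)Nc1nc2ccccc2s1`, is built on another core, and the difference between the two cores is not broken down here; in this assay compound 3 gives 36500 nM. The values of compound 1, compound 2 and compound 3 all lie within the scatter of each other, so none of the three can be placed above or below another.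

Compound 4, `CCOc1ccc2nc(NC(=S)Nc3ccccc3)sc2c1`, stands to compound 3 as compound 1 stands to compound 2: the change ethoxy in place of hydrogen on an aromatic carbon is the same one already seen, at a place described in the same words, so it counts as the same change made on the core of compound 3. Because a 1.3-fold higher number from compound 2 to compound 1 (0.11 log units; within the scatter) stayed within the scatter, compound 4 is expected to stay close to its parent in this assay, with the expected step being a 1.2-fold higher number from compound 3 to compound 4 (0.06 log units; within the scatter). That expectation rests on one earlier example only, made on a different core, so it is held loosely. Compound 4 is accordingly estimated at 42000 nM, expected to fall between 20000 nM and 90000 nM.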

Compound 4, half-maximal inhibitory concentration: 43800 nM
Compound 4: the middle estimate sits 1.0-fold (0.02 log units) below what was measured; the range from low to high includes it.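

In this assay, ethoxy in place of hydrogen on an aromatic carbon gave a 1.2-fold higher number from compound 3 to compound 4 (0.08 log units; within the scatter), and the same change on the two cores gave steps that cannot be told apart: the same change on two cores in this assay, a 1.3-fold higher number (0.11 log units; within the scatter) from compound 2 to compound 1 and a 1.2-fold higher number (0.08 log units; within the scatter) from compound 3 to compound 4, 1.1-fold (0.03 log units) apart, within the scatter of two such steps. On the compounds shown, then, the change carried from the core of compound 1 to the core of compound 3 without either step leaving the scatter, and the two steps agree in size as far as such measurements can tell. This does not show that ethoxy truly raises the number on either core, since both steps are small enough to be scatter alone, and two cores cannot say how the change would behave on a third.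

The compounds shown leave open what other groups would do in place of that hydrogen on the aromatic carbon, such as an amine, a carboxylic acid or a longer chain than ethoxy. They also leave open whether any change on these two cores can move the number beyond the scatter in this assay, as every comparison among compound 1, compound 2, compound 3 and compound 4 printed so far stays within it.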